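This account rests on a few compounds, and the source may have more. Where it says the series, first, only, none or still open, it means among the compounds named here.

Notes on the series built on the shared core of compound 2 `COc1cc(-c2nn(-c3ccc(NC(=O)Nc4ccc(Cl)c(C(F)(F)F)c4)cc3)cc2-c2ccncc2)ccc1Cl`. In a functional assay on MDA-MB-435 cells (Homo sapiens) for antiproliferative activity, read by sulforhodamine B assay, with a stated time of 48 h (on this read-out lower numbers stand for stronger inhibition and higher numbers for weaker inhibition), compound 1 `COc1cc(-c2nn(-c3ccc(NC(=O)Nc4ccc(Cl)c(Cl)c4)cc3)cc2-c2ccncc2)ccc1Cl` gives 2870 nM, compound 2 gives 1600 nM and compound 3 `COc1cc(-c2nn(-c3ccc(NC(=O)Nc4cc(C(F)(F)F)cc(C(F)(F)F)c4)cc3)cc2-c2ccncc2)ccc1Cl` gives 1880 nM. Compound 2 shows the lowest of the three numbers, but its gaps to compound 1 and to compound 3 both lie within the scatter, so the three cannot be separated. Among the measured compounds shown here, the only single-point step measured, a 1.8-fold lower number from compound 1 to compound 2 (0.25 log units; within the scatter), is within the scatter. Compound 4 `COc1cc(-c2nn(-c3ccc(NC(=O)c4cc(Cl)cc(Cl)c4)cc3)cc2-c2ccncc2)ccc1Cl` differs from compound 2 by 3,5-dichlorophenyl in place of (4-chloro-3-(trifluoromethyl)phenyl)amino on a carbonyl carbon. For the measured compounds named here, no measured step touches the carbonyl carbon or the amide-type nitrogen; the measured step concerns a ring substituent only, so the direction is open. The step is expected to be a 2.2-fold higher number from compound 2 to compound 4 (0.34 log units; beyond the scatter), with wide uncertainty. For compound 4 the estimate in this assay is 3500 nM, ranging from 900 nM to 14000 nM.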

Compound 4, half-maximal inhibitory concentration: > 100000 nM
Compound 4: only a limit was reported; the forecaster's own chance of this, stated with the estimate: 10%; at least 28-fold (1.45 log units) between middle value and limit.
By their numbers in this assay, from the lowest: compounds 2, 3 and 1 (each within the scatter of the next). At a limit, above all of these: compound 4.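

Compound 4 gives no number in this assay, only a limit: the limit of > 100000 nM in this assay, at which 1 of the 4 values shown sits. Among the compounds shown here, the change on the carbonyl carbon is large, an at least 62-fold higher number from compound 2 to compound 4 (1.79 log units; beyond the scatter) and an at least 34-fold higher number from compound 1 to compound 4 (1.54 log units; beyond the scatter), whereas the only earlier step, a ring-substituent change, stayed within the scatter. This position therefore matters far more to the read-out than the ring substituents compared so far.

The amino link and the ring substituents change together in compound 4, so their contributions remain unseparated. A (3,5-dichlorophenyl)amino group or a benzylamino group on the carbonyl carbon would be informative here.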